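The compounds below may be only part of what the source reports. "The series", "measured", "known", "first", "only" and "open" are said of these compounds alone.

Of the compounds shown here, two that share one core have been measured in a functional assay on the whole organism (strain albino) for inhibition, with Rattus norvegicus as the target, read by paw edema, with stated times of 1 h and 3 h, at a dose of 20 mmol/kg by the intraperitoneal route; a lower number here means a weaker effect, a higher number a stronger effect of the compound at the dose given. Compound 1, `N#CC1=C(NCC(=O)N2CCCC2)N(c2ccccc2)C(=O)N2CCCCC(N3CCCC3)C12`, gives 56%. Within the data shown here, compound 2, `COC(=O)C(=O)NC1=C(C#N)C2C(N3CCCC3)CCCCN2C(=O)N1c1ccccc1`, gives 88.3%, the higher of the two numbers; the only step among the measured compounds, a number 32.3 percentage points higher from compound 1 to compound 2 (beyond the scatter), separates them. Compound 3, `N#CC1=C(N)N(c2ccccc2)C(=O)N2CCCCC(N3CCCC3)C12`, has not yet been measured. It differs from compound 2 in one place: hydrogen in place of (methoxycarbonyl)carbonyl on an amine nitrogen. Among the measured compounds shown here, no measured step removes a substituent from this amine nitrogen altogether; the one step seen only exchanges one substituent on that nitrogen for another, and it shows that what sits there can shift this assay strongly. Compound 3 carries neither group. Its result is therefore expected to fall between the two measured numbers, with the step of a number 28.3 percentage points lower from compound 2 to compound 3 (beyond the scatter) estimated as a loss from compound 2. For compound 3 the estimate is 60%, with a range from 35% to 85%.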

Compound 3, a percentage reported as inhibition, in the whole organism at one dose (the size of the read-out at that dose, not a potency): 90.1%
Compound 3: the middle estimate sits 30.1 percentage points below what was measured, outside the stated range (above it).
By their numbers in this assay, from the lowest: compound 1; then compounds 2 and 3 (each within the scatter of the next).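

In this assay, the amine nitrogen needs no (methoxycarbonyl)carbonyl group: with hydrogen in its place there is a number 1.8 percentage points higher from compound 2 to compound 3 (within the scatter), so the numbers for the two compounds cannot be told apart. The low number of compound 1 therefore does not reflect a general penalty for substitution on this nitrogen, but goes with the ((pyrrolidin-1-yl)carbonyl)methyl group, as the unsubstituted amine shows with a number 34.1 percentage points higher from compound 1 to compound 3 (beyond the scatter). Nothing available accounts for this difference between the two substituents.

On these data alone, whether a plain methyl or acetyl group on this amine nitrogen would group with compound 2 and compound 3 or with compound 1 stays open. As far as these compounds go, all three numbers come from a single dose, so whether compound 2 and compound 3 also match in potency remains open too.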